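The source may hold more compounds than are shown below. What is called first, only, known or untested is meant among the compounds shown, and "the series" means these compounds.

Three compounds of this series carry a measured value. Compound 1 `O=C(Nc1cccc(-n2cc(-c3ccncc3)c(-c3cc(O)cc(Cl)c3)n2)c1)Nc1ccc(Cl)c(C(F)(F)F)c1` gives in a functional assay on IGROV-1 cells (Homo sapiens) for inhibition, read by sulforhodamine B assay, with a stated time of 48 h, tested at 0.01 uM (on this read-out lower numbers stand for a stronger effect and higher numbers for a weaker effect at the one concentration tested), 94%. Compound 2 `O=C(Nc1cccc(-n2cc(-c3ccncc3)c(-c3cc(O)cc(Cl)c3)n2)c1)Nc1ccc(Cl)c(Cl)c1` gives in this assay 98%, the second highest of the three numbers; its nearest neighbour is compound 1, its furthest compound 3 `COc1cc(Cl)cc(-c2nn(-c3cccc(NC(=O)Nc4cc(C(F)(F)F)cc(C(F)(F)F)c4)c3)cc2-c2ccncc2)c1`, which in this assay gives 103%. All three numbers lie close together, near no inhibition at the single concentration used. Among the measured compounds shown here, the only single-point step among them, a number 4 percentage points higher from compound 1 to compound 2 (within the scatter), is within the scatter.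

Compound 4 `COc1cc(Cl)cc(-c2nn(-c3cccc(NC(=O)Nc4ccc(Cl)c(Cl)c4)c3)cc2-c2ccncc2)c1` is not yet measured. It differs from compound 2 by methyl in place of hydrogen on an oxygen on an aromatic ring. For the measured compounds named here, no measured step covers this change on its own; compound 3 carries the methoxy group but differs from compound 2 in a second place as well, so only the two values can be set side by side, and they sit within the scatter of each other. With every measured value near the top of the scale and no step beyond the scatter anywhere in the set, the expectation for this assay is a number 2 percentage points higher from compound 2 to compound 4 (within the scatter), a step of no real size. Compound 4 is therefore estimated at 100%, within a range of 88% to 110%.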

Compound 4, a percentage reported as activity, at one concentration (the size of the read-out at that concentration, not a potency): 98%
For compound 4 the middle estimate is 2 percentage points above the measured one; the range from low to high includes it.
By their numbers in this assay, from the lowest: compounds 1, 2, 4 and 3 (each within the scatter of the next).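

Hydroxy to methoxy, read as 3-chloro-5-hydroxyphenyl to 3-chloro-5-methoxyphenyl, now stands alone as a single change: in this assay the series gives no change at the digits printed from compound 2 to compound 4 (within the scatter) as its step. Among the compounds shown here, until now the methoxy group appeared only together with a second difference, so this is the first reading of methyl in place of hydrogen on this oxygen by itself, and at this position the change leaves no mark on the read-out. No measurement at hand offers an explanation for this result.

Both compounds stand near no inhibition at the single concentration used, so the step cannot tell whether this change would matter in a compound with a clear effect. From the compounds shown here alone, whether a longer chain on this oxygen, such as ethyl, or an amine in place of the hydroxy group would shift the number remains open.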